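A few compounds are considered here, and "the series" means these few. Any claim that something is new, unique, unknown or untested is made for them only; others in the source may bear on it.

Compound 2 `Cc1cccc(Cn2cc(CCCCC[C@@H]3SC[C@@H]4NC(=O)N[C@@H]43)nn2)c1` carries a 3-methylbenzyl group on the shared core. In an assay on isolated protein for inhibition of biotin--protein ligase (Homo sapiens), read by scintillation counting, with a stated time of 10 min (a lower number here means a stronger inhibitor, a higher number a weaker inhibitor), compound 2 reaches only a limit, > 16000 nM. Compound 1 `COc1cccc(Cn2cc(CCCCC[C@@H]3SC[C@@H]4NC(=O)N[C@@H]43)nn2)c1` likewise stops at a limit in this assay, > 16000 nM. Compound 3 `O=C1N[C@H]2[C@H](CS[C@H]2CCCCCc2cn(Cc3ccccc3Cl)nn2)N1` also gives only a limit in this assay, > 16000 nM. Thus (the limit of > 16000 nM in this assay, at which 3 of the 3 values shown sit), and the two measured steps that touch compound 2, a step that the two limits leave unreadable from compound 1 to compound 2 and a step that the two limits leave unreadable from compound 2 to compound 3, cannot be sized. Compound 4 `O=C1N[C@H]2[C@H](CS[C@H]2CCCCCc2cn(Cc3cccc(Cl)c3)nn2)N1` differs from compound 2 by chloro in place of methyl on an aromatic carbon. Going by the values given here, because of the limit of > 16000 nM in this assay, at which 3 of the 3 values shown sit, no measured step gives a readable direction for this change, so no step beyond the scatter is expected, and a further limit is the likeliest outcome. Compound 4 is therefore estimated at 25000 nM, within 8000 nM to 80000 nM. The expected step is a step that the limit leaves unreadable from compound 2 to compound 4.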

Compound 4, inhibition constant: > 16000 nM
Compound 4: no number, only a limit (the forecaster's own chance of this, stated with the estimate: 85%); the middle value lies beyond the limit too.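

The steps from compound 1, compound 2 and compound 3 to compound 4 cannot be read, as each pair ends at a limit: the limit of > 16000 nM in this assay, at which 4 of the 4 values shown sit.

The compounds shown leave open which change to the shared core, if any, would give a readable value in this assay.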